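A 4-fluorobenzyl group replaces 2-methylbenzyl on sulfur

A few compounds are considered here, and "the series" means these few. Any claim that something is new, unique, unknown or untested is made for them only; others in the source may bear on it.

- compound 1 `Sc1nnc(-c2ccc3c(c2)OCCO3)n1-c1ccccc1` gives 38400 nM
- compound 2 `Cc1ccccc1CSc1nnc(-c2ccc3c(c2)OCCO3)n1-c1ccccc1` gives 12700 nM

In a functional assay on SW 1116 cells (Homo sapiens) for antiproliferative activity, read by MTT assay, with a stated time of 24 h (a lower number here means a stronger inhibitor, a higher number a weaker inhibitor), compound 2 holds the lower of the two numbers. Compound 3 `Fc1ccc(CSc2nnc(-c3ccc4c(c3)OCCO4)n2-c2ccccc2)cc1` keeps the shared core and differs from it by one exchange (4-fluorophenyl in place of 2-methylphenyl on a saturated chain carbon bound to a sulfur). For the measured compounds named here, the only measured step that bears on this, a 3.0-fold lower number from compound 1 to compound 2 (0.48 log units; beyond the scatter), put 2-methylbenzyl in place of hydrogen on a sulfur and was modest. No measurement compares one benzyl group with another, so no step beyond the scatter is expected, in either direction. For compound 3 the estimate is 13000 nM, with an expected range from 5500 nM to 30000 nM. This estimate means an expected 1.0-fold higher number from compound 2 to compound 3 (0.01 log units; within the scatter).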

Compound 3, half-maximal inhibitory concentration: 20800 nM
Estimate against measurement, compound 3: 1.6-fold (0.20 log units) below, within the range that was stated.
By their numbers in this assay, from the lowest: compounds 2, 3 and 1 (each within the scatter of the next, the first and the last beyond it).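

In this assay, 4-fluorophenyl in place of 2-methylphenyl on a saturated chain carbon bound to a sulfur gives a 1.6-fold higher number from compound 2 to compound 3 (0.21 log units; within the scatter) and so does not separate these two benzyl groups. Starting from hydrogen on the sulfur, 4-fluorobenzyl gives a 1.8-fold lower number from compound 1 to compound 3 (0.27 log units; within the scatter) and stays within the scatter, whereas the step to 2-methylbenzyl lay beyond it. No evidence at hand bears on this result. Still open, on these data alone, is whether a longer chain on the sulfur, or a carboxylic acid in place of the fluorine, would move the number beyond the scatter.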